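Ester variation in a calcium channel antagonist series

A few compounds are considered here, and "the series" means these few. Any claim that something is new, unique, unknown or untested is made for them only; others in the source may bear on it.

Measured compounds:
- compound 1 `CCOC(=O)C1=C(C)NC(C)=C(C(=O)OC)C1c1csc(-c2ccc(Cl)cc2)n1`: 22000 nM
- compound 2 `CCOC(=O)C1=C(C)NC(C)=C(C(=O)OCC(C)C)C1c1csc(-c2ccc(Cl)cc2)n1`: 15400 nM
- compound 3 `COC(=O)C1=C(C)NC(C)=C(C(=O)OCCc2ccccc2)C1c1csc(-c2ccc(Cl)cc2)n1`: 10200 nM

All three were run in an assay on isolated protein for antagonist activity at Voltage-dependent L-type calcium channel subunit alpha-1C (Cavia porcellus), with a stated time of 15 min; on this read-out higher numbers stand for weaker inhibition and lower numbers for stronger inhibition. Compound 3 gives the lowest number of the three: against compound 2 the gap is within the scatter, against compound 1 it is the step of a 2.2-fold lower number from compound 1 to compound 3 (0.33 log units; beyond the scatter).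

Compound 4 `CCOC(=O)C1=C(C)NC(C)=C(C(=O)OCCc2ccccc2)C1c1csc(-c2ccc(Cl)cc2)n1` has not been measured. It differs from compound 3 by methyl in place of hydrogen on a saturated chain carbon bound to an oxygen next to a carbonyl group. The measured step that bears on this place is a 1.4-fold lower number from compound 1 to compound 2 (0.15 log units; within the scatter), a larger group entering at the same carbon with no change beyond the scatter. The step of a 2.2-fold lower number from compound 1 to compound 3 (0.33 log units; beyond the scatter) concerns a group two bonds further along the chain and is only indirectly related. From the step from compound 1 to compound 2 no shift beyond the scatter is expected for compound 4; at most a slight lowering. The expected step is a 1.2-fold lower number from compound 3 to compound 4 (0.08 log units; within the scatter), giving for compound 4 an estimated 8500 nM, with a range from 4000 nM to 18000 nM.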

Compound 4, half-maximal inhibitory concentration: 12100 nM
Estimate against measurement, compound 4: 1.4-fold (0.15 log units) below; measured number inside the range.
By their numbers in this assay, from the lowest: compounds 3, 4, 2 and 1 (each within the scatter of the next, the first and the last beyond it).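

In this assay the methyl that turns methoxycarbonyl to ethoxycarbonyl, with the rest of the molecule unchanged, gives a 1.2-fold higher number from compound 3 to compound 4 (0.07 log units; within the scatter) and so produces no shift that can be told from the scatter. Benzyl in place of isopropyl gives a 1.3-fold lower number from compound 2 to compound 4 (0.10 log units; within the scatter) and benzyl in place of hydrogen gives a 1.8-fold lower number from compound 1 to compound 4 (0.26 log units; within the scatter) at this same carbon, so compound 4 is separated from neither compound 1 nor compound 2 by more than the scatter, although a 2.2-fold lower number from compound 1 to compound 3 (0.33 log units; beyond the scatter) stands beyond it. Nothing available accounts for these small steps.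

Going by these compounds, whether a longer chain or an amine at this carbon would move the number beyond the scatter stays open. Also open, on these data alone, is whether a carboxylic acid in place of either ester would do so.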